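Fluorophenyl to methoxypyridinyl: a step at the cytotoxicity limit

A few compounds are considered here, and "the series" means these few. Any claim that something is new, unique, unknown or untested is made for them only; others in the source may bear on it.

Compound 1, `N#Cc1ccc(-c2nc(CO[C@@H]3COc4nc([N+](=O)[O-])cn4C3)cs2)cc1`, in an ADME assay on Vero cells (Chlorocebus sabaeus) for cytotoxicity, with a stated time of 72 h (a higher number here means a weaker inhibitor, a lower number a stronger inhibitor), gives > 128000 nM, a limit of the assay rather than a number.
Compound 2, `O=[N+]([O-])c1cn2c(n1)OC[C@@H](OCc1csc(-c3ccc(F)cc3)n1)C2`, in this assay gives > 128000 nM, again only a limit.
Compound 3, `COc1ccc(-c2nc(CO[C@@H]3COc4nc([N+](=O)[O-])cn4C3)cs2)cc1F`, in this assay gives > 128000 nM, also a limit.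

Compound 3 therefore stands at the limit, as does every measured compound here; the limit of > 128000 nM in this assay, at which 3 of the 3 values shown sit, describes where all three values sit. The step from compound 1 to compound 2 is a step that the two limits leave unreadable from compound 1 to compound 2, the step from compound 1 to compound 3 is a step that the two limits leave unreadable from compound 1 to compound 3, and the step from compound 2 to compound 3 is a step that the two limits leave unreadable from compound 2 to compound 3. None of them can be read, so none shows any effect of changing the group on the five-membered ring.

Compound 4, `COc1ccc(-c2nc(CO[C@@H]3COc4nc([N+](=O)[O-])cn4C3)cs2)cn1`, has not been measured. It differs from compound 3 by 6-methoxypyridin-3-yl in place of 3-fluoro-4-methoxyphenyl on an aromatic carbon. Since the three measured steps all left the values at the same limit, no shift beyond the scatter in this assay is expected from this further swap of the aromatic group. The expected outcome for compound 4 is another limit. Compound 4 is estimated at 200000 nM, with a range from 100000 nM to 400000 nM. This estimate means a step that the limit leaves unreadable from compound 3 to compound 4, which is expected to be within the scatter.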

Compound 4, half-maximal inhibitory concentration: > 128000 nM
Compound 4: only a limit was reported; the forecaster's own chance of this, stated with the estimate: 85%; the middle value is on the limit's open side.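

The steps to compound 4 from compound 1, compound 2 and compound 3 cannot be read, because all of these compounds sit at the same limit: the limit of > 128000 nM in this assay, at which 4 of the 4 values shown sit.

The compounds shown leave open whether changing the aromatic group on the five-membered ring shifts the result in this assay at all, and by how much.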